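A few compounds are considered here, and "the series" means these few. Any claim that something is new, unique, unknown or untested is made for them only; others in the source may bear on it.

Measured so far in an ADME assay on microsomes from liver (Canis lupus familiaris) for metabolic stability; a lower number here means that the compound disappears faster, a higher number that the compound lasts longer:

- compound 1 `N#Cc1ccc(-c2nc(NCCNc3ccc([N+](=O)[O-])c(N)n3)ncc2-c2ncc[nH]2)cc1` gives > 0.5 h, which is a limit of the measurement and not a number.
- compound 2 `Nc1nc(NCCNc2ncc(-c3ncc[nH]3)c(-c3ccccc3Cl)n2)ccc1[N+](=O)[O-]` gives > 0.5 h, likewise a limit.
- compound 3 `Nc1nc(NCCNc2ncc(-c3ncc[nH]3)c(-c3cc(F)ccc3Cl)n2)ccc1[N+](=O)[O-]` gives > 0.5 h, likewise a limit.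

Where compound 1 stands, then, is known only as a boundary: in this assay compound 1 lasted beyond the point to which the measurement reaches, and no true half-life is attached to it. The same holds for every compound here, since (the limit of > 0.5 h in this assay, at which 3 of the 3 values shown sit).

Compound 4 `Nc1nc(NCCNc2ncc(-c3ncc[nH]3)c(-c3ccc(Br)cc3F)n2)ccc1[N+](=O)[O-]` differs from compound 1 in a single place.

4-bromo-2-fluorophenyl in place of 4-cyanophenyl on an aromatic carbon

The measured steps that touch this same place are a step that the two limits leave unreadable from compound 1 to compound 2 and a step that the two limits leave unreadable from compound 1 to compound 3; both are unreadable because of the limit of > 0.5 h in this assay, at which 3 of the 3 values shown sit. The step that the two limits leave unreadable from compound 2 to compound 3, a further change of the same ring, is unreadable for the same reason. These comparisons therefore offer no direction and no size to carry over. With nothing pointing the other way, compound 4 is expected to behave like its three relatives and to remain at the limit, so the expected step that the limit leaves unreadable from compound 1 to compound 4 is an estimate of no readable change. For compound 4 the estimated half-life is 1 h, with an expected range from 0.5 h to 3 h.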

Compound 4, half-life: > 0.5 h
Compound 4 gave a limit, no number (the forecaster's own chance of this, stated with the estimate: 80%); the middle value lies beyond the limit too.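

In this assay compound 4 gives > 0.5 h, a limit and not a number, so its steps to compound 1, compound 2 and compound 3 cannot be read: the limit of > 0.5 h in this assay, at which 4 of the 4 values shown sit.

The compounds shown leave open how long each truly lasts in this assay, and whether changing the substituted phenyl group alters that half-life at all.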